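The source may report more compounds than this note shows. Statements on the series, on what has been measured and on what is new or still open speak of the compounds shown alone.

Measured compounds in a functional assay on GTL 16 cells for antiproliferative activity against GTL 16 cell line (Homo sapiens), read by CCK-8 assay, with a stated time of 72 h; a higher number here means a weaker inhibitor, a lower number a stronger inhibitor:
compound 1 `Cc1ccc(C(=O)Nc2cccc(-c3oc4cc(-c5ccc(F)cc5)ccc4c(=O)c3O)c2)cc1`: 12900 nM
compound 2 `O=C(Nc1cccc(-c2oc3cc(-c4ccc(F)cc4)ccc3c(=O)c2O)c1)c1cccc(F)c1`: 15800 nM
compound 3 `COc1cc(OC)cc(C(=O)Nc2cccc(-c3oc4cc(-c5ccc(F)cc5)ccc4c(=O)c3O)c2)c1`: 19600 nM

Compound 1 gives the smallest number of the three, yet its steps to the others, a 1.2-fold higher number from compound 1 to compound 2 (0.09 log units; within the scatter) and a 1.5-fold higher number from compound 1 to compound 3 (0.18 log units; within the scatter), stay within the scatter, so the three compounds cannot be separated in this assay. Compound 4 `O=C(Nc1cccc(-c2oc3cc(-c4ccc(F)cc4)ccc3c(=O)c2O)c1)c1ccc(Cl)nc1` differs from compound 1 in one place: 6-chloropyridin-3-yl in place of 4-methylphenyl on a carbonyl carbon. Every measured step exchanges the aryl group on this carbonyl carbon, and each of them, including a 1.2-fold higher number from compound 2 to compound 3 (0.09 log units; within the scatter), is within the scatter. The expectation is therefore that the step of a 1.2-fold higher number from compound 1 to compound 4 (0.09 log units; within the scatter) also stays within the scatter, with no direction favoured. For compound 4 the estimate in this assay is 16000 nM, with a range from 8000 nM to 32000 nM.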

Compound 4, half-maximal inhibitory concentration: 7520 nM
Estimate against measurement, compound 4: 2.1-fold (0.33 log units) above; measured number outside the range, below it.
By their numbers in this assay, from the lowest: compounds 4, 1, 2 and 3 (each within the scatter of the next, the first and the last beyond it).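

In this assay, going by these compounds alone, exchanging the aryl group on this carbonyl carbon now gives separations beyond the scatter for the first time, though both are modest: a 2.6-fold lower number from compound 3 to compound 4 (0.42 log units; beyond the scatter) and a 2.1-fold lower number from compound 2 to compound 4 (0.32 log units; beyond the scatter). Against the 4-methylphenyl group, however, 6-chloropyridin-3-yl cannot be separated, as a 1.7-fold lower number from compound 1 to compound 4 (0.23 log units; within the scatter) stays within the scatter. No measurement at hand accounts for these steps.

Left open is whether the ring nitrogen or the chlorine matters, which a plain pyridin-3-yl or a 4-chlorophenyl on this carbonyl carbon could separate. From the compounds shown here alone, how an amine or a carboxylic acid on this ring would read also remains open.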